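Trading the selenium chain for methylsulfanyl in compound 4

A few compounds are considered here, and "the series" means these few. Any claim that something is new, unique, unknown or untested is made for them only; others in the source may bear on it.

Compound 1, `OCC#CCSc1cnc2ccccc2c1[Se]CC#CCBr`: 0.2 ug/mL
Compound 2, `OCC#CCSc1cnc2ccccc2c1[Se]CC#CCO`: 1.4 ug/mL
Compound 3, `OCC#CCSc1cnc2ccccc2c1SCC#CCO`: 2.6 ug/mL

These three compounds share a core and were all tested in a functional assay on CCRF-CEM cells (Homo sapiens) for cytotoxicity, read by sulforhodamine B assay, with a stated time of 72 h; a higher number here means a weaker inhibitor, a lower number a stronger inhibitor. Compound 2 gives the second highest of the three numbers: compound 3 is nearest, with a 1.9-fold higher number from compound 2 to compound 3 (0.27 log units; within the scatter), and compound 1 is furthest, with a 7.0-fold higher number from compound 1 to compound 2 (0.85 log units; beyond the scatter).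

Compound 4, `CSc1c(SCC#CCO)cnc2ccccc12`, differs from compound 2 in one place: a group of 2 heavy atoms (1 carbon, 1 sulfur; no ring) in place of a group of 6 heavy atoms (4 carbon, 1 oxygen, 1 selenium; no ring), on an aromatic carbon.

Going by the values given here, two measured steps bear on this. The step of a 1.9-fold higher number from compound 2 to compound 3 (0.27 log units; within the scatter) shows that swapping selenium for sulfur inside the group of 6 heavy atoms changes little. The step of a 13-fold higher number from compound 1 to compound 3 (1.11 log units; beyond the scatter) shows that the group of 6 heavy atoms on that aromatic carbon can matter a great deal, while a 7.0-fold higher number from compound 1 to compound 2 (0.85 log units; beyond the scatter) shows that hydroxy in place of bromo alone is a modest step. Compound 4 removes the whole group of 6 heavy atoms in favour of methylsulfanyl, a change larger than any measured step covers, so the estimate carries real uncertainty.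

On that basis the number for compound 4 is expected to rise moderately, by about a 2.9-fold higher number from compound 2 to compound 4 (0.46 log units; beyond the scatter). For compound 4 the estimated value in this assay is 4 ug/mL, with a range from 1.2 ug/mL to 15 ug/mL.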

Compound 4, concentration for 50% inhibition: 13.9 ug/mL
The estimate for compound 4 lay 3.5-fold (0.54 log units) below the measured number, within the range that was stated.
By their numbers in this assay, from the lowest: compound 1; then compounds 2 and 3 (each within the scatter of the next); then compound 4.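

In this assay, cutting the group on this aromatic carbon, opposite the ring nitrogen, down to methylsulfanyl gives a 9.9-fold higher number from compound 2 to compound 4 (1.00 log units; beyond the scatter), a step beyond the scatter, whereas the swap of selenium for sulfur stayed within it. The most direct view is a 5.3-fold higher number from compound 3 to compound 4 (0.73 log units; beyond the scatter), where sulfur stays on the ring and only the 3-hydroxyprop-1-yn-1-yl part of the chain gives way to hydrogen, so the length of the chain beyond that sulfur matters for the number and not just the atom that holds it. The widest gap at this position is a 70-fold higher number from compound 1 to compound 4 (1.84 log units; beyond the scatter), which puts the chain ending in bromo at the low end of the series and the short methylsulfanyl at the high end. Nothing measured here gives a reason for this rise.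

Still open, going by these compounds, is whether a short chain such as ethylsulfanyl or propylsulfanyl would fall between methylsulfanyl and the full chain. On these data alone, it is also open whether an amine or a carboxylic acid at the end of the full chain would give numbers closer to those of the hydroxy compounds or to that of the bromo compound.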